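The source may hold more compounds than are shown below. What is called first, only, known or untested is meant among the compounds shown, and "the series" means these compounds.

Measured compounds in an ADME assay on cells (Homo sapiens) for antiproliferative activity, read by MTT assay; on this read-out higher numbers stand for weaker inhibition and lower numbers for stronger inhibition: compound 1 `O=C(NN=C(c1ccccn1)c1ccccn1)c1cccc(Br)c1` gives 240 nM; compound 2 `O=C(NN=C(c1ccccn1)c1ccccn1)c1ccncc1` gives 830 nM; compound 3 `O=C(NN=C(c1ccccn1)c1ccccn1)c1ccc(C(F)(F)F)cc1` gives 240 nM.

Compound 3 stands level with compound 1 at the digits shown, the two together being the lowest of the three numbers; compound 2 lies furthest from it. Compound 4 `O=C(NN=C(c1ccccn1)c1ccccn1)c1ccc(Br)cc1` differs from compound 3 by bromo in place of trifluoromethyl on an aromatic carbon.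

Among the measured compounds shown here, the only step measured so far, a 3.5-fold higher number from compound 1 to compound 2 (0.54 log units; beyond the scatter), swaps the whole aryl group for a pyridyl and does not bear on an exchange of one substituent for another on the same ring. Compound 1, which already carries a bromo on that ring, and compound 3 show no difference at the digits shown, so the same is expected here, no change at the digits printed from compound 3 to compound 4 (within the scatter). Compound 4 is therefore estimated at 240 nM, with a range of 110 nM to 520 nM.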

Compound 4, half-maximal inhibitory concentration: 300 nM
Compound 4: the middle estimate sits 1.3-fold (0.10 log units) below what was measured, and the stated range covers the measured number.
By their numbers in this assay, from the lowest: compounds 1, 3 and 4 (each within the scatter of the next); then compound 2.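

In this assay, bromo in place of trifluoromethyl on the aromatic carbon para to a large group gives (a 1.3-fold higher number from compound 3 to compound 4 (0.10 log units; within the scatter)), so this position holds either group without a change beyond the scatter. 4-Bromophenyl in place of 3-bromophenyl also stays within the scatter (a 1.3-fold higher number from compound 1 to compound 4 (0.10 log units; within the scatter)), whereas 4-bromophenyl in place of pyridin-4-yl gives (a 2.8-fold lower number from compound 2 to compound 4 (0.44 log units; beyond the scatter)). No measurement shown speaks to the reason for these numbers.

From the compounds shown here alone, whether an amine or a carboxylic acid at this position would stay at the same level remains open. So does the effect of a longer chain there.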